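Swapping Methyl for Phenyl: What Compound 4 Might Need

The source may hold more compounds than are shown below. What is called first, only, known or untested is meant among the compounds shown, and "the series" means these compounds.

Of the compounds shown here, three have been tested in a functional assay on the whole organism (stomach) with Rattus norvegicus as the target; a lower number here means that less compound is needed, a higher number that more compound is needed for the effect. Compound 1 `N=C(S)CCn1nc(-c2ccccc2)ccc1=S` gives 73.4 mg/kg in this assay. Compound 2 `Cc1ccc(=S)n(CCC(=N)S)n1` carries a methyl where compound 1 carries a phenyl; in this assay compound 2 gives 100 mg/kg. For compound 3 `Cc1ccc(=O)n(CCCCCCC(=N)S)n1`, this assay reports only a limit, > 100 mg/kg, and not a number. The measured step between the first two is a 1.4-fold lower number from compound 2 to compound 1 (0.13 log units; within the scatter), and the change behind it is phenyl in place of methyl on an aromatic carbon.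

Compound 4 `N=C(S)CCCCCCn1nc(-c2ccccc2)ccc1=O` has not yet been measured in this assay. It stands to compound 3 as compound 1 stands to compound 2: the change is phenyl in place of methyl on an aromatic carbon. The two place lines are not identical, since in compound 2 the site is meta to a group of 5 heavy atoms while in compound 3 it is meta to a group of 9 heavy atoms, so this is the same kind of change rather than the same one. How the core of compound 3 differs from the core of compound 2 is not broken down here.

The earlier step from compound 2 to compound 1 stayed within the scatter, so the step from compound 3 to compound 4 is expected to be of similar size, a number no higher from compound 3 to compound 4 (the limit leaves the size open). Since compound 3 sits at the limit of > 100 mg/kg in this assay, at which 1 of the 3 values shown sits, compound 4 is expected to give about 100 mg/kg, between 55 mg/kg and 200 mg/kg, with a real chance that this assay again reports only a limit.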

Compound 4, dose for half-maximal effect: > 100 mg/kg
Compound 4: only a limit was reported; the forecaster's own chance of this, stated with the estimate: 65%; the middle value sits exactly at the limit.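

In this assay, compound 3 and compound 4 both give only a limit and not a number, so the step between them cannot be read, because neither compound has an exact value to compare: the limit of > 100 mg/kg in this assay, at which 2 of the 4 values shown sit.

The compounds shown leave open whether phenyl in place of methyl on an aromatic carbon changes the number between compound 3 and compound 4 at all, and if so, by how much.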